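The compounds below may be only part of what the source reports. "The series", "measured", "known", "first", "only" and "open" are said of these compounds alone.

Measured in a functional assay on A549 cells (Homo sapiens), read by MTT assay, with a stated time of 72 h; on this read-out higher numbers stand for weaker inhibition and lower numbers for stronger inhibition:
Compound 1 `CSc1ncnc2c1c(-c1ccoc1)cn2[C@@H]1O[C@H](CO)[C@@H](O)[C@H]1O`: 280 nM
Compound 2 `CNc1ncnc2c1c(-c1ccco1)cn2[C@@H]1O[C@H](CO)[C@@H](O)[C@H]1O`: 2570 nM

Of these two compounds, compound 2 has the higher number and therefore shows the weaker inhibition, and its gap to compound 1 lies beyond the usual scatter of repeated measurements. The next compound to be tested, compound 3 `CNc1ncnc2c1c(-c1ccsc1)cn2[C@@H]1O[C@H](CO)[C@@H](O)[C@H]1O`, differs from compound 2 in one place: it has thiophen-3-yl in place of furan-2-yl on an aromatic carbon. The two measured compounds differ from each other in more than one place, so they give no direct measure of what this single swap does. Any forecast is therefore loose. Compound 1, at 280 nM, shows that a close relative can reach a lower number than compound 2 at 2570 nM, so the expectation leans slightly downward. The expected change is a 1.7-fold lower number from compound 2 to compound 3 (0.23 log units; within the scatter), a small fall that would stay within the usual scatter. For compound 3 the estimated value is 1500 nM, with an expected range from 350 nM to 7000 nM.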

Compound 3, half-maximal inhibitory concentration: > 20000 nM
Compound 3: a limit, no number; the forecaster's own chance of this, stated with the estimate: 15%; middle value at least 13-fold (1.12 log units) from the limit.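

In this assay, for the compounds shown here, putting thiophen-3-yl in place of furan-2-yl on this aromatic carbon gives an at least 7.7-fold higher number from compound 2 to compound 3 (0.89 log units; beyond the scatter), the first direct reading of a single change at this position, and it lies beyond the scatter. The result for compound 3 is a limit of the assay and not a number, so the step has a known minimum but no known full size: the limit of > 20000 nM in this assay, at which 1 of the 3 values shown sits.

The two groups have the same number of heavy atoms, the same count of hydrogen-bond donors and acceptors, no net charge, and each is one five-membered aromatic ring with one hetero atom, so these counts alone do not decide the outcome at this position.

The swap changes two things at once, the hetero atom from oxygen to sulfur and the ring position through which the group is attached, and the compounds shown cannot separate these two changes. Thiophen-2-yl on the same carbon, with the rest of compound 2 kept, would change only the hetero atom and so would show how much of the step comes from sulfur alone.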